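Dropping both chlorines from the aryl group of compound 3

A few compounds are considered here, and "the series" means these few. Any claim that something is new, unique, unknown or untested is made for them only; others in the source may bear on it.

Compound 1, `Clc1ccc(Cc2nn3c(Br)c(-c4ccc(Cl)cc4)nc3s2)cc1`, gives in a functional assay on HeLa cells (Homo sapiens) for cytotoxicity, with a stated time of 72 h (on this read-out lower numbers stand for stronger inhibition and higher numbers for weaker inhibition), only a limit of the assay, > 250000 nM. Compound 2, `COc1ccc(-c2nc3sc(Cc4ccc(Cl)cc4)nn3c2Br)cc1`, gives 66000 nM. Compound 3, `Clc1ccc(Cc2nn3c(Br)c(-c4ccc(Cl)cc4Cl)nc3s2)cc1`, gives 118000 nM.

Among the two numbers that are not limits, compound 3 has the highest, and its nearest neighbour is compound 2, the two lying within the scatter of each other. Compound 4, `Clc1ccc(Cc2nn3c(Br)c(-c4ccccc4)nc3s2)cc1`, has not yet been measured. It differs from compound 3 in one place: phenyl in place of 2,4-dichlorophenyl on an aromatic carbon.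

Going by the values given here, two measured steps bear on this change. The step of an at least 2.1-fold lower number from compound 1 to compound 3 (0.32 log units; beyond the scatter) shows that adding a chloro to the aryl group lowered the number beyond the scatter; compound 4 goes the opposite way, removing both chlorines. The step of a 1.8-fold higher number from compound 2 to compound 3 (0.25 log units; within the scatter) lies within the scatter and so adds little. Compound 1, which still carries one chloro on that ring, sits at the limit, (the limit of > 250000 nM in this assay, at which 1 of the 3 values shown sits).

Compound 4 is therefore expected to give a higher number, estimated as a 2.1-fold higher number from compound 3 to compound 4 (0.33 log units; beyond the scatter), quite possibly reaching the limit again. The estimate for compound 4 is 250000 nM, with a range from 100000 nM to 600000 nM.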

Compound 4, half-maximal inhibitory concentration: > 250000 nM
Compound 4: a limit, no number; the forecaster's own chance of this, stated with the estimate: 50%; the middle value sits exactly at the limit.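

Taking both chlorines off this ring gives a real loss of activity in this assay, with an at least 2.1-fold higher number from compound 3 to compound 4 (0.32 log units; beyond the scatter), and the phenyl compound also falls away from the methoxy compound, with an at least 3.7-fold higher number from compound 2 to compound 4 (0.57 log units; beyond the scatter). A measurable number at this position therefore appears only with the 2,4-dichlorophenyl group of compound 3 and the methoxy-bearing ring of compound 2, whereas the bare phenyl ring does not reach one, and compound 1 shows that a substituted ring alone is not enough. Compound 1 and compound 4 both rest at the limit, so the step between them cannot be read: the limit of > 250000 nM in this assay, at which 2 of the 4 values shown sit.

On these data alone, the true values of those two compounds therefore remain unknown, and with them any effect of the single chloro. Also open, as far as these compounds go, is how an amine or a carboxylic acid on this ring would read out in this assay.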